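The source may hold more compounds than are shown below. What is called first, only, known or untested is meant among the compounds shown, and "the series" means these compounds.

In an assay on LX2 cells for inhibition of COL1A1 promoter (Homo sapiens), read by a luciferase reporter, with a stated time of 24 h, tested at 50 uM (a higher number here means a stronger effect of the compound at the concentration tested, a lower number a weaker effect), compound 1, whose structure is `Cc1cc(-n2cc(C(=O)Nc3cc(F)cc(F)c3)c(=O)c3ccc(N(C)C)nc32)ccc1OCCCCCCC[N+]1(C)CCCC1`, gives 35.9%. Compound 2, `CN(C)c1ccc2c(=O)c(C(=O)Nc3cc(F)cc(F)c3)cn(-c3ccc(OCCCCCCC[N+]4(C)CCCC4)c(Cl)c3)c2n1`, differs from it by chloro in place of methyl on an aromatic carbon, and in this assay compound 2 gives 2.59%, so that the change a number 33.3 percentage points lower from compound 1 to compound 2 (beyond the scatter). Compound 3, `Cc1cc(OCCCCCCC[N+]2(C)CCCCC2)ccc1-n1cc(C(=O)Nc2cc(F)cc(F)c2)c(=O)c2ccc(N(C)C)nc21`, shares much of this framework, but the difference between its core and the core of compound 1 is not broken down here; in this assay compound 3 gives "not active" (no number reported), with no number reported. Compound 4, `CN(C)c1ccc2c(=O)c(C(=O)Nc3cc(F)cc(F)c3)cn(-c3ccc(OCCCCCCC[N+]4(C)CCCCC4)cc3Cl)c2n1`, is the unmeasured partner of compound 3, carrying (chloro in place of methyl on an aromatic carbon), the same change that separates compound 1 from compound 2. That change in this assay a number 33.3 percentage points lower from compound 1 to compound 2 (beyond the scatter), a large fall from an already moderate starting point. Since compound 3 itself gave no number and was called not active, the same replacement is expected to leave compound 4 with little room to fall further, and any effect is expected to remain small. The estimate for compound 4 in this assay is 3%, with an expected range from 0% to 15%.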

Compound 4, a percentage reported as inhibition, at one concentration (the size of the read-out at that concentration, not a potency): "not active" (no number reported)
Nothing numeric was reported for compound 4; no gap can be computed for the estimate.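

In this assay compound 3 gives "not active" (no number reported) and compound 4 gives "not active" (no number reported), so no step can be read between them. Nothing shown here accounts for this result. The compounds shown leave open whether chloro in place of methyl changes the effect in this pair as it does between compound 1 and compound 2.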